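From 3-(4-methylphenoxy)propyl to 4-phenoxybutyl

The source may report more compounds than this note shows. Statements on the series, on what has been measured and on what is new or still open speak of the compounds shown alone.

Measured in a functional assay on HCT-116 cells (Homo sapiens) for antiproliferative activity, read by MTT assay, with a stated time of 48 h; on this read-out higher numbers stand for weaker inhibition of growth and lower numbers for stronger inhibition of growth:
compound 1 `CCCCCN(Cc1ccc(C(=O)NO)cc1)c1ncc(-c2ccc(C)cc2)s1`: 23300 nM
compound 2 `Cc1ccc(OCCCN(Cc2ccc(C(=O)NO)cc2)c2ncc(-c3ccc(C)cc3)s2)cc1`: 12600 nM

Within the data shown here, compound 2, at 12600 nM, stands within the scatter of compound 1, the only other measured compound. Compound 3 `Cc1ccc(-c2cnc(N(CCCCOc3ccccc3)Cc3ccc(C(=O)NO)cc3)s2)cc1` has the same atoms as compound 2, joined differently: phenoxymethyl in place of 4-methylphenoxy on a saturated chain carbon, three bonds along the chain from a nitrogen on an aromatic ring. A 3-(4-methylphenoxy)propyl chain thus gives way to 4-phenoxybutyl. Among the measured compounds shown here, the one measured step that bears on this is a 1.8-fold lower number from compound 1 to compound 2 (0.27 log units; within the scatter), a change of ethyl to 4-methylphenoxy at the same place. No step beyond the scatter is therefore expected in this assay, and the expected step is a 1.0-fold higher number from compound 2 to compound 3 (0.01 log units; within the scatter). For compound 3 the estimated value is 13000 nM, with an expected range of 6000 nM to 27000 nM.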

Compound 3, concentration for 50% growth inhibition: 680 nM
The estimate for compound 3 lay 19-fold (1.28 log units) above the measured number; measured number outside the range, below it.
By their numbers in this assay, from the lowest: compound 3; then compounds 2 and 1 (each within the scatter of the next).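

In this assay, the same atoms joined differently are not interchangeable at this place: phenoxymethyl in place of 4-methylphenoxy gives a 19-fold lower number from compound 2 to compound 3 (1.27 log units; beyond the scatter), whereas the earlier change on this chain stayed within the scatter. Phenoxy in place of methyl, four bonds along the chain from a nitrogen on an aromatic ring, likewise gives a 34-fold lower number from compound 1 to compound 3 (1.53 log units; beyond the scatter). Growth inhibition at this chain therefore responds strongly to how the chain and its terminal aryl ether are arranged.

Nothing available accounts for the size of these steps. The chain length and the methyl on the phenoxy ring change together, so the shown compounds leave open which one matters, and whether 4-(4-methylphenoxy)butyl, 5-phenoxypentyl or a terminal amine would keep the stronger inhibition.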